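The source may report more compounds than this note shows. Statements on the series, on what has been measured and on what is new or still open speak of the compounds shown alone.

Working notes on the series. Compound 1 `O=C(O)CN1C(=O)/C(=C/c2nc3ccccc3n2Cc2ccc(Br)cc2)SC1=S` is the reference point; in a functional assay on HeLa cells (Homo sapiens) for cytotoxicity, read by MTT assay, with a stated time of 48 h (a lower number here means a stronger inhibitor, a higher number a weaker inhibitor), compound 1 gives 12900 nM. Among the measured compounds shown here, the only other measured compound is compound 2 `N#Cc1ccc(Cn2c(/C=C3\SC(=S)N(CC(=O)O)C3=O)nc3ccccc32)cc1`, which in this assay gives 16300 nM. The step of a 1.3-fold higher number from compound 1 to compound 2 (0.10 log units; within the scatter) is the sole measured comparison, and it places compound 1 and compound 2 within the scatter of each other, so compound 1 stands apart from nothing on the numbers shown.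

Compound 3 `O=C(O)CN1C(=O)/C(=C/c2nc3ccccc3n2Cc2ccc(F)cc2F)SC1=S` differs from compound 1 as follows: 2,4-difluorophenyl in place of 4-bromophenyl on a saturated chain carbon bound to an aromatic nitrogen. The change sits at the same part of the molecule as the change from compound 1 to compound 2, where swapping one group for another on that ring gave a 1.3-fold higher number from compound 1 to compound 2 (0.10 log units; within the scatter). For the measured compounds named here, no measured step tests a second fluorine on that ring, so the expectation rests on that single comparison.

The expected outcome for compound 3 in this assay is therefore no step beyond the scatter, a 1.1-fold higher number from compound 1 to compound 3 (0.04 log units; within the scatter). Compound 3 is estimated at 14000 nM, with a range from 5000 nM to 40000 nM.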

Compound 3, half-maximal inhibitory concentration: 26100 nM
Beside the measured number, compound 3's estimate is 1.9-fold (0.27 log units) below it; the range from low to high includes it.
By their numbers in this assay, from the lowest: compounds 1, 2 and 3 (each within the scatter of the next, the first and the last beyond it).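

In this assay, 2,4-difluorophenyl in place of 4-bromophenyl on a saturated chain carbon bound to an aromatic nitrogen gives a 2.0-fold higher number from compound 1 to compound 3 (0.31 log units; beyond the scatter), so this position now shows a step beyond the scatter, although a modest one. The same group in place of 4-cyanophenyl gives a 1.6-fold higher number from compound 2 to compound 3 (0.20 log units; within the scatter), which leaves the three compounds as a chain in which only compound 1 and compound 3 are separated, while compound 2 cannot be set apart from either. Nothing available on these compounds bears on what lies behind the step from 4-bromophenyl to 2,4-difluorophenyl.

This change removes the bromine and brings in two fluorines at once, so the compounds shown cannot assign the step to either part of it, and a single-fluorine 4-fluorophenyl or an unsubstituted phenyl on the same carbon would be needed to divide it. All three compounds also keep the same substitution type at this position, halogens or a nitrile on the ring, which leaves open how an amine or a methoxy group on that ring, or a longer chain in place of the benzyl carbon, would read in this assay.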